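The compounds below may be only part of what the source reports. "The series", "measured", "known", "first", "only" and "open" are said of these compounds alone.

Measured compounds:
- compound 1, `Cc1ccccc1C(=O)Nc1ccc(S(=O)(=O)NC2CCN(C(=O)CCCCN)CC2)c2ccccc12`: 199 nM
- compound 2, `Cc1ccccc1C(=O)Nc1ccc(S(=O)(=O)NC2CCN(C(=O)[C@@H]3CCCN3)CC2)c2ccccc12`: 0.7 nM; 1 nM (2 entries)

In an assay on L1.2 cells for binding affinity to C-C chemokine receptor type 8 (Homo sapiens) (a higher number here means a weaker inhibitor, a lower number a stronger inhibitor), compound 1 gives 199 nM, which is the weaker of the two numbers shown, since compound 2 gives 0.7 nM; 1 nM (2 entries) (the several entries of compound 2 in this assay, 0.7 nM; 1 nM (2 entries)). Compound 3, `Cc1ccccc1C(=O)Nc1ccc(S(=O)(=O)NC2CCN(C(=O)NC(C)C)CC2)c2ccccc12`, is not yet measured in this assay. It differs from compound 1 by isopropylamino in place of 4-aminobutyl on a carbonyl carbon: the 4-aminobutyl chain is exchanged for an isopropylamino group on the carbonyl carbon, so that the (4-aminobutyl)carbonyl becomes an isopropylcarbamoyl. Within the data shown here, no measured pair mirrors this exchange. The step is expected to be a 1.8-fold higher number from compound 1 to compound 3 (0.25 log units; within the scatter), a modest weakening that may not clearly exceed the scatter. Compound 3 is therefore estimated at 350 nM, within 60 nM to 2500 nM.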

Compound 3, inhibition constant: 77.7 nM
The estimate for compound 3 lay 4.5-fold (0.65 log units) above the measured number; low and high end bracket the measured number.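

On the carbonyl carbon whose other neighbour is the amide-type nitrogen in a ring, the 4-aminobutyl chain proves dispensable: in this assay, isopropylamino in its place gives a 2.6-fold lower number from compound 1 to compound 3 (0.41 log units; beyond the scatter). This position therefore accepts an isopropylcarbamoyl as well as the (4-aminobutyl)carbonyl of compound 1. Nothing measured here accounts for the step.

The compounds shown leave open whether the isopropyl part or the nitrogen on the carbonyl carbon carries the step. They also leave open how a cyclopropylamino group, a tert-butylamino group or a plain isopropyl group would read there.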